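The source may hold more compounds than are shown below. What is called first, only, known or untested is meant among the compounds shown, and "the series" means these compounds.

Measured so far in a functional assay on MCF7 cells (Homo sapiens) for cytotoxicity, read by MTT assay, with a stated time of 24 h; on this read-out lower numbers stand for stronger inhibition and higher numbers for weaker inhibition:
Compound 1 `O=C(NC(=S)Nc1nc2ccccc2s1)c1ccccc1` gives 37300 nM.
Compound 2 `Nc1ccc2sc(NC(=S)NC(=O)c3ccc([N+](=O)[O-])cc3)nc2c1` gives 33200 nM.
Compound 3 `O=C(NC(=S)Nc1nc2cc(Br)ccc2s1)c1ccc([N+](=O)[O-])cc1` gives 32400 nM.

Compound 3 has the lowest of the three numbers in this assay, but its gaps to compound 2 and to compound 1 are both within the usual scatter, so the three compounds cannot be told apart on these data. Among the compounds with values here, the only single-point step recorded, a 1.0-fold lower number from compound 2 to compound 3 (0.01 log units; within the scatter), likewise moved nothing beyond the scatter.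

Compound 4 `O=C(NC(=S)Nc1nc2ccccc2s1)c1ccc([N+](=O)[O-])cc1` differs from compound 3 by hydrogen in place of bromo on an aromatic carbon. The measured step that bears on this change is a 1.0-fold lower number from compound 2 to compound 3 (0.01 log units; within the scatter), which installed that same bromo group in place of an amino group without shifting the number; removing the bromo group is therefore not expected to shift it either. Compound 1, which also carries no substituent at that place but differs from compound 4 in a second place as well, sits in the same band, which supports the same view.

Compound 4 is expected to give about 34000 nM in this assay, with a plausible range of 17000 nM to 68000 nM. The expected step is a 1.0-fold higher number from compound 3 to compound 4 (0.02 log units; within the scatter), that is, no change beyond the scatter.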

Compound 4, half-maximal inhibitory concentration: 33800 nM
For compound 4 the middle estimate is 1.0-fold (0.00 log units) above the measured one; low and high end bracket the measured number.
By their numbers in this assay, from the lowest: compounds 3, 2, 4 and 1 (each within the scatter of the next).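

Swapping hydrogen for bromo on this aromatic carbon (a 1.0-fold higher number from compound 3 to compound 4 (0.02 log units; within the scatter)) and hydrogen for amino there (a 1.0-fold higher number from compound 2 to compound 4 (0.01 log units; within the scatter)) both stay within the scatter. With the rest of the molecule held fixed, hydrogen, bromo and amino therefore cannot be told apart at this place in this assay and compound 4 gives the position its plain reference point. Compound 4 also opens a one-place comparison at a different aromatic carbon, where nitro in place of hydrogen (a 1.1-fold lower number from compound 1 to compound 4 (0.04 log units; within the scatter)) likewise stays within the scatter.

Going by these compounds, whether a carboxylic acid or a longer chain such as butyl at either place would move the number away from this band remains open. No measurement at hand gives a reason why these changes leave the number where it is.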